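A Second Chlorine on the Core of Compound 1

The source may report more compounds than this note shows. Statements on the series, on what has been measured and on what is new or still open speak of the compounds shown alone.

Compound 1, with the structure `O=C1c2ccccc2N(Cc2ccccc2)S(=O)(=O)N1Cc1ccc(Cl)cc1`, was tested in a functional assay on HEL cells (Homo sapiens) (on this read-out higher numbers stand for lower toxicity in this test and lower numbers for higher toxicity in this test), and gave 20000 nM. Within the data shown here, that is the lowest of the two numbers measured so far, meaning the higher toxicity of the pair. Its closest neighbour is compound 2, `O=C1c2ccccc2N(Cc2ccccc2)S(=O)(=O)N1COCc1ccccc1`, which in this assay gives 49000 nM; the step of a 2.5-fold higher number from compound 1 to compound 2 (0.39 log units; beyond the scatter) follows from putting benzyloxy in place of 4-chlorophenyl on a saturated chain carbon bound to an amide-type nitrogen in a ring.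

Compound 3, `O=C1c2ccccc2N(Cc2ccc(Cl)cc2)S(=O)(=O)N1Cc1ccc(Cl)cc1`, has not yet been measured. It differs from compound 1 by chloro in place of hydrogen on an aromatic carbon: phenyl becomes 4-chlorophenyl, benzyl becomes 4-chlorobenzyl. Among the measured compounds shown here, no measured step covers a change of this kind or at this place; the only step known alters a different group. With nothing to draw on, the expectation for compound 3 in this assay is a number close to that of compound 1, with no step beyond the scatter, so the estimate is 20000 nM, between 8000 nM and 50000 nM, an expected step of no change at the digits printed from compound 1 to compound 3 (within the scatter).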

Compound 3, minimum cytotoxic concentration: > 50000 nM
Compound 3 ended at the assay's limit; the forecaster's own chance of this, stated with the estimate: 10%; middle value at least 2.5-fold (0.39 log units) from the limit.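

The earlier step changed only the group carrying the 4-chlorophenyl, so it said nothing about the benzyl group of compound 1. This result shows that the benzyl group counts too: in this assay, chloro in place of hydrogen on its aromatic ring, a change of one heavy atom, gives an at least 2.5-fold higher number from compound 1 to compound 3 (0.39 log units; beyond the scatter), a shift towards lower toxicity in this test. Compound 3 gives > 50000 nM, which is a limit of the assay and not a number, so the step has a known lower bound but no known full size: the limit of > 50000 nM in this assay, at which 1 of the 3 values shown sits.

The compounds shown leave open whether this step is particular to chloro or would also follow from another group at the same place on the ring, such as fluoro, methoxy or an amine. They also leave open whether the same chloro placed on the benzyl group of compound 2, which carries benzyloxy on the other side of the shared core rather than 4-chlorophenyl, would bring a step of similar direction.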